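This account rests on a few compounds, and the source may have more. Where it says the series, first, only, none or still open, it means among the compounds named here.

Series notes. In a functional assay on MCF7 cells (Homo sapiens) for cytotoxicity, read by MTT assay, with a stated time of 24 h (a lower number here means a stronger inhibitor, a higher number a weaker inhibitor), compound 1 `NCCNC(=O)Cn1nc(N)c2c(C(F)(F)F)cc(-c3ccccc3)nc21` gives 42900 nM, and compound 2 `Nc1nn(CC(=O)NCc2ccccc2)c2nc(-c3ccccc3)cc(C(F)(F)F)c12` gives 16300 nM. For the measured compounds named here, the one step measured so far, a 2.6-fold lower number from compound 1 to compound 2 (0.42 log units; beyond the scatter), is the only comparison available, so compound 2 holds the lower of the two numbers and compound 1 is its sole neighbour.

Compound 3 `Nc1nn(CC(=O)NCC(=O)O)c2nc(-c3ccccc3)cc(C(F)(F)F)c12` is the next member: carboxy in place of phenyl on a saturated chain carbon bound to an amide-type nitrogen. Going by the values given here, no measured step shows carboxy entering at this position. Among the compounds with values here, the one step that bears on the change, a 2.6-fold lower number from compound 1 to compound 2 (0.42 log units; beyond the scatter), shows that phenyl on this chain carbon went with the lower number; its removal in favour of a small polar substituent is therefore expected to move this assay back toward the larger numbers, by a step of about a 2.5-fold higher number from compound 2 to compound 3 (0.39 log units; beyond the scatter), though with an open range. For compound 3 the expected value in this assay is 40000 nM, within 14000 nM to 110000 nM.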

Compound 3, half-maximal inhibitory concentration: 21200 nM
Estimate against measurement, compound 3: 1.9-fold (0.28 log units) above; the range from low to high includes it.
By their numbers in this assay, from the lowest: compounds 2 and 3 (each within the scatter of the next); then compound 1.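

In this assay, carboxy in place of phenyl on the saturated chain carbon bound to the amide-type nitrogen gives a 1.3-fold higher number from compound 2 to compound 3 (0.11 log units; within the scatter) and so leaves no readable difference: the six-membered aromatic ring is not needed to reach the level of compound 2 in this pair. Carboxy in place of aminomethyl gives a 2.0-fold lower number from compound 1 to compound 3 (0.31 log units; beyond the scatter) as a modest step, so two unlike groups, phenyl and carboxy, now both stand apart from aminomethyl, and compound 1 alone holds the highest number. The data at hand give no reason for either step.

From the compounds shown here alone, whether a methyl ester or primary amide in place of the carboxylic acid, or a longer chain carrying the carboxy, would stay with compound 2 and compound 3 remains open. So does whether a longer chain carrying the amine would move away from compound 1.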